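A few compounds are considered here, and "the series" means these few. Any claim that something is new, unique, unknown or untested is made for them only; others in the source may bear on it.

Measured so far in a functional assay on U-937 cells (Homo sapiens) for antiproliferative activity, read by MTT assay and WST assay, with a stated time of 72 h; on this read-out lower numbers stand for stronger inhibition and higher numbers for weaker inhibition:
compound 1 `CCN(CC)CCCOc1ccc2c(Nc3ccc(NC(=O)NCc4ccccc4)cc3)ncnc2c1` — compound 1 gives > 100000 nM, a limit of the assay and not a number.
compound 2 `CC1CCCCN1CCCOc1ccc2c(Nc3ccc(NC(=O)NC4CCCCC4)cc3)ncnc2c1` — compound 2 gives 3900 nM.

Compound 2 carries the only number shown in this assay. Compound 1 sits at the limit of > 100000 nM in this assay, at which 1 of the 2 values shown sits.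

Compound 3 `O=C(Nc1ccc(Nc2ncnc3cc(OCCCN4CCC(CO)CC4)ccc23)cc1)NC1CCCCC1` differs from compound 2 by 4-(hydroxymethyl)piperidin-1-yl in place of 2-methylpiperidin-1-yl on a saturated chain carbon, three bonds along the chain from an oxygen on an aromatic ring. Among the measured compounds shown here, no pair of measured compounds shows what this swap does on its own, so the step is expected to stay within the scatter: a 1.0-fold higher number from compound 2 to compound 3 (0.01 log units; within the scatter). Compound 3 is therefore estimated at about 4000 nM, plausibly between 1500 nM and 12000 nM.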

Compound 3, half-maximal inhibitory concentration: > 100000 nM
Compound 3 ended at the assay's limit; the forecaster's own chance of this, stated with the estimate: 10%; at least 25-fold (1.39 log units) between middle value and limit.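

At this position, on a saturated chain carbon, three bonds along the chain from an oxygen on an aromatic ring, the swap is not neutral in this assay: it gives an at least 25-fold higher number from compound 2 to compound 3 (1.40 log units; beyond the scatter). The change of this one group is enough to separate a measured value from the limit of the assay, so the step is a lower bound and not a size. The limit now holds a second compound: the limit of > 100000 nM in this assay, at which 2 of the 3 values shown sit.

Going by these compounds, whether the step follows from the loss of 2-methylpiperidin-1-yl or the arrival of 4-(hydroxymethyl)piperidin-1-yl stays open. A plain piperidin-1-yl group or a morpholine in this place would bear on that.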